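Replacing carbamoyl with methoxy on a shared core

This account rests on a few compounds, and the source may have more. Where it says the series, first, only, none or still open, it means among the compounds named here.

Compound 1, `Cc1cc(NC(=O)Nc2ccccc2OC(F)(F)F)c2ccccc2n1`: 4600 nM
Compound 2, `Cc1cc(NC(=O)Nc2ccccc2C(N)=O)c2ccccc2n1`: 200 nM

In a physicochemical assay for solubility, at pH 7.4 (a lower number here means a less soluble compound, a higher number a more soluble compound), compound 2 holds the lower of the two numbers, beyond the scatter from compound 1. Compound 3, `COc1ccccc1NC(=O)Nc1cc(C)nc2ccccc12`, has methoxy in place of carbamoyl on an aromatic carbon, ortho to a large group (methoxy in place of carbamoyl on an aromatic carbon). Going by the values given here, one measured step bears on this change, the large 23-fold lower number from compound 1 to compound 2 (1.36 log units; beyond the scatter). Its reversal suggests a higher number, and a large step is expected, though methoxy is not trifluoromethoxy. The expected step is a 10-fold higher number from compound 2 to compound 3 (1.00 log units; beyond the scatter). Compound 3 is estimated at 2000 nM, within an expected range from 500 nM to 8000 nM.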

Compound 3, solubility: 100 nM
Compound 3: the middle estimate sits 20-fold (1.30 log units) above what was measured; the whole stated range lies above it.
By their numbers in this assay, from the lowest: compounds 3 and 2 (each within the scatter of the next); then compound 1.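

In this assay, methoxy and carbamoyl on this aromatic carbon, ortho to a large group, cannot be told apart (a 2.0-fold lower number from compound 2 to compound 3 (0.30 log units; within the scatter)). The low number is therefore not peculiar to carbamoyl: methyl in place of trifluoromethyl on the oxygen also gives a large step (a 46-fold lower number from compound 1 to compound 3 (1.66 log units; beyond the scatter)), leaving compound 1 alone at the high end. Nothing available explains these results.

Open, going by these compounds, is where other groups at this position would fall, such as an amine, a carboxylic acid or a longer ether chain. On these data alone, whether any of them would approach compound 1 or stay with compound 2 and compound 3 remains unknown.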